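The compounds below may be only part of what the source reports. "The series", "measured", "known", "first", "only" and "open" are said of these compounds alone.

Working notes on the series. Compound 1 `CCCCNc1nc(N)nc(C)c1CCCn1c(C)nc2ccccc21`, compound 2 `CCCCNc1nc(N)nc(C)c1CCCN1Cc2ccccc2C1` and compound 3 `CCCCNc1nc(N)nc(C)c1CCCC(C)(C)O` share one core and differ only in the group at the end of the three-carbon chain. In an assay on HEK293 cells for agonist activity at Toll-like receptor 8 (Homo sapiens), read by spectrophotometry (a higher number here means that more compound is needed for the effect, a lower number that less compound is needed), compound 1 gives 366 nM, compound 2 gives 29 nM, and compound 3 gives 1220 nM. Compound 3 thus stands highest of the three, with compound 1 nearest and compound 2 furthest, both gaps beyond the scatter. Compound 4 `CCCCNc1nc(N)nc(C)c1CCCN1CCCC1` has not been measured. The change from compound 3 is pyrrolidin-1-yl in place of 1-hydroxy-1-methylethyl on a saturated chain carbon, three bonds along the chain from an aromatic carbon. Compound 2, which also carries a saturated nitrogen ring at that position, sits far below compound 3; on that basis the expected step of a 20-fold lower number from compound 3 to compound 4 (1.31 log units; beyond the scatter) is downward, well beyond the scatter. Compound 4 is expected near 60 nM, with a range from 15 nM to 250 nM.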

Compound 4, half-maximal effective concentration: 110 nM
Compound 4: the middle estimate sits 1.8-fold (0.26 log units) below what was measured; the measured number falls inside the stated range.
By their numbers in this assay, from the lowest: compound 2; then compound 4; then compound 1; then compound 3.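

In this assay, pyrrolidin-1-yl in place of 1-hydroxy-1-methylethyl on a saturated chain carbon gives an 11-fold lower number from compound 3 to compound 4 (1.04 log units; beyond the scatter), so this position responds strongly to this change of end group. A simple five-membered nitrogen ring is enough for a large step, although compound 4 at 110 nM stays numerically above compound 2 at 29 nM. Nothing available bears on the cause of this step.

From the compounds shown here alone, whether the ring itself matters remains open, since an open-chain dimethylamino group at this place would separate ring from nitrogen. Going by these compounds, a piperidine or morpholine ring, or a longer chain, also remains untested here.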